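The compounds below may be only part of what the source reports. "The series", "measured", "known", "first", "only" and "open" are said of these compounds alone.

Measured in a physicochemical assay for solubility, read by LC-MS, in phosphate buffer, with a stated time of 24 h, at pH 7.4; on this read-out lower numbers stand for lower solubility and higher numbers for higher solubility:
- compound 1 `CC(=O)Nc1cc(Nc2cc(NC3CC3)n3ncc(C#N)c3n2)ccc1N1CC[C@@H](N)C1`: 812000 nM
- compound 2 `CC(=O)Nc1cc(Nc2cc(NC3CC3)n3ncc(C#N)c3n2)ccc1N1CC[C@H](N)C1`: 590000 nM
- compound 3 `CC(=O)Nc1cc(Nc2cc(NC3CC3)n3ncc(C#N)c3n2)ccc1N1CCC[C@H](N)C1`: 704000 nM

All three numbers sit within the usual scatter of one another, so compound 1 cannot be set apart from compound 2 or compound 3 on these readings. Compound 4 `CC(=O)Nc1cc(Nc2cc(NC3CC3)n3ncc(C#N)c3n2)ccc1N1CCC[C@@H](N(C)C)C1` is not yet measured. It differs from compound 1 in one place: a group of 9 heavy atoms (7 carbon, 2 nitrogen; one six-membered non-aromatic ring with 1 hetero atom) in place of a group of 6 heavy atoms (4 carbon, 2 nitrogen; one five-membered non-aromatic ring with 1 hetero atom), on an aromatic carbon. The nearest measured step is the ring change from compound 1 to compound 3, which gave a 1.2-fold lower number from compound 1 to compound 3 (0.06 log units; within the scatter). For the measured compounds named here, no measured step covers the exchange of the amino group for a dimethylamino group. On this basis, the step of a 1.2-fold lower number from compound 1 to compound 4 (0.10 log units; within the scatter) is expected to stay within the scatter. Compound 4 is therefore estimated at 650000 nM, with a range of 300000 nM to 1300000 nM.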

Compound 4, solubility: > 900000 nM
Compound 4: a limit, no number; the forecaster's own chance of this, stated with the estimate: 5%; middle value at least 1.3-fold (0.14 log units) from the limit.
By their numbers in this assay, from the lowest: compounds 2, 3 and 1 (each within the scatter of the next). At a limit, above all of these: compound 4.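

In this assay, compound 4 gives a limit of the assay and not a number: > 900000 nM. Its steps can therefore be read only as floors: an at least 1.1-fold higher number from compound 1 to compound 4 (0.04 log units; that floor lies within the scatter), an at least 1.2-fold higher number from compound 3 to compound 4 (0.10 log units; that floor lies within the scatter) and an at least 1.5-fold higher number from compound 2 to compound 4 (0.18 log units; that floor lies within the scatter). So, at this position on the aromatic carbon, a ring carrying a dimethylamino group in place of the amino group shows no fall in the number, though the true size of each step stays unknown.

Still open, from the compounds shown here alone, are the real value of compound 4 and how a diethylamino group or a carboxylic acid on the same ring would read.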